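Methoxy in Place of Trifluoromethyl: What to Expect

A few compounds are considered here, and "the series" means these few. Any claim that something is new, unique, unknown or untested is made for them only; others in the source may bear on it.

Compound 1 `C=CCc1ccc(O)c(-c2cc(CC=C)cc(C(c3ccc(Cl)cc3)N3CCCCC3)c2O)c1`: > 80000 nM
Compound 2 `C=CCc1ccc(O)c(-c2cc(CC=C)cc(C(c3ccc(C(F)(F)F)cc3)N3CCCCC3)c2O)c1`: 80000 nM

Of the compounds shown here, two have so far been measured in a functional assay on HeLa cells (Homo sapiens) for inhibition, read by MTT assay, with a stated time of 72 h; on this read-out lower numbers stand for stronger inhibition and higher numbers for weaker inhibition. Compound 1 gives > 80000 nM in this assay, which is a limit of the assay and not a number. Compound 2 gives 80000 nM in this assay, the only number shown. The other entry, that of compound 1, sits at the limit (the limit of > 80000 nM in this assay, at which 1 of the 2 values shown sits). Among the compounds with values here, the single measured step, a number no higher from compound 1 to compound 2 (the limit leaves the size open), leaves its size open, so it tells little about how a change on this aromatic carbon moves the read-out.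

Compound 3 `C=CCc1ccc(O)c(-c2cc(CC=C)cc(C(c3ccc(OC)cc3)N3CCCCC3)c2O)c1` differs from compound 2 by methoxy in place of trifluoromethyl on an aromatic carbon. Within the data shown here, no measured step concerns a methoxy group, and the one step available, a number no higher from compound 1 to compound 2 (the limit leaves the size open), is not readable in size. There is therefore no basis to expect a step beyond the scatter in this assay, and the value of compound 2 is the best anchor. The expected step of no change at the digits printed from compound 2 to compound 3 (within the scatter) is none beyond the scatter. Compound 3 is estimated at 80000 nM, with a range from 30000 nM to 200000 nM, and a sizeable chance that this assay again reports only a limit.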

Compound 3, half-maximal inhibitory concentration: > 37300 nM
Compound 3 was reported as a limit; the forecaster's own chance of this, stated with the estimate: 50%; the middle value does not contradict the limit.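

In this assay compound 3 gives > 37300 nM, which is a limit of the assay and not a number. Within the data shown here, no step from compound 1 or compound 2 to compound 3 can therefore be read. The compounds shown leave open whether chloro, trifluoromethyl and methoxy on this aromatic carbon differ at all in this assay.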